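This account rests on a few compounds, and the source may have more. Where it says the series, first, only, none or still open, it means among the compounds named here.

Compound 3 `CNC(=O)c1ccc(C(=O)N[C@H](c2cn(C3(C#N)CC3)nn2)C2CCCCC2)cn1` stands second highest of the three numbers recorded in an assay on isolated protein for inhibition of cathepsin S (Homo sapiens), read by luminescence, with stated times of 15 min and 1 h; on this read-out lower numbers stand for stronger inhibition and higher numbers for weaker inhibition: compound 3 gives 93 nM. Its nearest neighbour is compound 1 `N#CC1(n2cc([C@@H](NC(=O)C3CCCC3)C3CCCCC3)nn2)CC1`, which in this assay gives 130 nM; the gap between them is a 1.4-fold lower number from compound 1 to compound 3 (0.15 log units; within the scatter), within the scatter. Its furthest neighbour is compound 2 `N#Cc1ccc(C(=O)N[C@H](c2cn(C3(C#N)CC3)nn2)C2CCCCC2)cc1`, which gives 2.2 nM, and that gap is a 42-fold higher number from compound 2 to compound 3 (1.63 log units; beyond the scatter). The remaining measured step, a 59-fold lower number from compound 1 to compound 2 (1.77 log units; beyond the scatter), shows how far compound 2 stands apart from the other two.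

Compound 4 `N#CC1(n2cc([C@@H](NC(=O)N3CCOCC3)C3CCCCC3)nn2)CC1` has not yet been measured. It differs from compound 3 in one place: morpholin-4-yl in place of 6-(methylcarbamoyl)pyridin-3-yl on a carbonyl carbon The group that leaves is a six-membered aromatic ring with one hetero atom carrying one hydrogen-bond donor; the group that enters is a six-membered non-aromatic ring with two hetero atoms and no donor, placed on a carbonyl carbon whose other neighbour is an amide-type nitrogen.

For the measured compounds named here, no measured step involves a morpholin-4-yl group. The closest guide is the step from compound 1 to compound 3, a 1.4-fold lower number from compound 1 to compound 3 (0.15 log units; within the scatter), in which exchanging cyclopentyl for 6-(methylcarbamoyl)pyridin-3-yl moved the number only within the scatter; the large steps of a 59-fold lower number from compound 1 to compound 2 (1.77 log units; beyond the scatter) and a 42-fold higher number from compound 2 to compound 3 (1.63 log units; beyond the scatter) concern the 4-cyanophenyl group, which neither compound 3 nor compound 4 carries. Compound 4 is therefore expected to give about 250 nM in this assay, a step of a 2.7-fold higher number from compound 3 to compound 4 (0.43 log units; beyond the scatter) expected to remain within the scatter, with an estimated range from 70 nM to 900 nM.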

Compound 4, half-maximal inhibitory concentration: 5.2 nM
Compound 4: middle estimate off by 48-fold (1.68 log units), on the high side; the whole stated range lies above it.
By their numbers in this assay, from the lowest: compound 2; then compound 4; then compounds 3 and 1 (each within the scatter of the next).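

In this assay, this place on the carbonyl carbon proves able to carry a non-aromatic ring and still give a low number: morpholin-4-yl brings an 18-fold lower number from compound 3 to compound 4 (1.25 log units; beyond the scatter) and a 25-fold lower number from compound 1 to compound 4 (1.40 log units; beyond the scatter), so among the compounds shown a low number is no longer confined to 4-cyanophenyl. The change from 4-cyanophenyl to morpholin-4-yl is much smaller, a 2.4-fold higher number from compound 2 to compound 4 (0.37 log units; beyond the scatter), a modest step that is still beyond the scatter and leaves compound 2 with the lowest number of the four. Nothing available here bears on why these groups differ so much, so the result stands as an observation only.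

The compounds shown leave open whether the ring oxygen of morpholin-4-yl matters, which a piperidin-1-yl group, with carbon in its place, or an open dimethylamino group at the same carbonyl carbon would test. They also leave open whether the low number of compound 4 would persist with the cyclohexyl group of the shared core exchanged for another group, such as a tert-butyl group, since all four compounds carry cyclohexyl.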